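The source may report more compounds than this note shows. Statements on the series, on what has been measured and on what is new or still open speak of the compounds shown alone.

Measured compounds:
compound 1 `CC(C)n1nc(C(=O)O)cc1[C@@H]1C[C@H]1c1ccc(OCc2c(-c3c(Cl)cccc3Cl)noc2C2CC2)cc1Cl` gives 4 nM in an assay on HEK293 cells for agonist activity at Bile acid receptor (Homo sapiens); on this read-out lower numbers stand for an effect already at smaller amounts and higher numbers for an effect only at larger amounts of compound.
compound 2 `O=C(O)c1cccc(C2CC2c2ccc(OCc3c(-c4c(Cl)cccc4Cl)noc3C3CC3)cc2Cl)c1` gives 34 nM in this assay.

Of the two numbers, compound 2 stands highest: its nearest neighbour is compound 1, whose value sits well beyond the scatter below it. Compound 3 `O=C(O)c1cccc([C@@H]2C[C@H]2c2ccc(OCc3c(-c4c(Cl)cccc4Cl)noc3C3CC3)cc2Cl)c1` is the next compound to be measured in this assay. It differs from compound 2 as follows: the two compounds have the same atoms and bonds; at least one stereo element is drawn with a configuration in one of them and without one in the other: 2 of 2 stereo elements differ; a stereocentre at a saturated ring carbon is drawn without a configuration in compound 2 and R in compound 3; a stereocentre at a saturated ring carbon is drawn without a configuration in compound 2 and R in compound 3. Going by the values given here, no step between two measured compounds is available to guide this change, so the expectation rests on the drawn configuration alone. Where a compound drawn without configuration is replaced by one drawn with a single configuration at both centres, the number is commonly expected to move downward by a moderate amount, though it may also stay within the scatter. Compound 3 is therefore expected to give about 15 nM in this assay, within a range of 5 nM to 45 nM, which means an expected step of a 2.3-fold lower number from compound 2 to compound 3 (0.36 log units; beyond the scatter).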

Compound 3, half-maximal effective concentration: 29 nM
Estimate against measurement, compound 3: 1.9-fold (0.29 log units) below, and the stated range covers the measured number.
By their numbers in this assay, from the lowest: compound 1; then compounds 3 and 2 (each within the scatter of the next).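

In this assay, drawing both saturated ring carbons with a defined configuration gives a 1.2-fold lower number from compound 2 to compound 3 (0.07 log units; within the scatter), so the drawn configuration does not separate these two compounds on this read-out. All that distinguishes them is this: the fact that one of compounds 2 and 3 is drawn with a defined configuration and the other without, at the place where they differ. With the configuration now drawn alike in both, the exchange of 3-carboxyphenyl in place of 3-carboxy-1-isopropyl-1H-pyrazol-5-yl on a saturated ring carbon can be read as a single change, and it is a clear one: a 7.3-fold higher number from compound 1 to compound 3 (0.86 log units; beyond the scatter).

The compounds shown leave open how the opposite configuration at the two saturated ring carbons would read in this assay. They also leave open whether a tetrazole in place of the carboxylic acid, or a methyl in place of the isopropyl of compound 1, would keep the value measured for compound 1, 4 nM.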